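This account rests on a few compounds, and the source may have more. Where it says the series, first, only, none or still open, it means among the compounds named here.

Measured so far in a physicochemical assay for lipophilicity; a higher number here means a more lipophilic compound, a lower number a more polar compound:
compound 1 `CC(C)(C)C#Cc1cc(N(C(=O)[C@H]2CC[C@H](C)CC2)[C@H]2CC[C@](O)(CO[C@H]3CCOC3)CC2)c(C(=O)O)s1`: 2.4
compound 2 `CC(C)(C)C#Cc1cc(N(C(=O)[C@H]2CC[C@H](C)CC2)[C@H]2CC[C@@H](Oc3ccc(=O)[nH]n3)CC2)c(C(=O)O)s1`: 1.8
compound 3 `CC(C)(C)C#Cc1cc(N(C(=O)[C@H]2CC[C@H](C)CC2)[C@H]2CC[C@H](OC3COC3)CC2)c(C(=O)O)s1`: 2.6

Compound 3 at 2.6 stands within the scatter of compound 1 at 2.4. Compound 2 at 1.8 lies lower than compound 3, beyond the scatter.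

Compound 4 `CC(C)(C)C#Cc1cc(N(C(=O)[C@H]2CC[C@H](C)CC2)[C@H]2CC[C@H](Oc3ccc(=O)[nH]n3)CC2)c(C(=O)O)s1` has not yet been measured. Its structural change from compound 3 is a group of 7 heavy atoms (4 carbon, 2 nitrogen, 1 oxygen; one six-membered aromatic ring with 2 hetero atoms) in place of a group of 4 heavy atoms (3 carbon, 1 oxygen; one four-membered non-aromatic ring with 1 hetero atom), on an oxygen on a saturated carbon. The oxetan-3-yl leaves, and a group with one six-membered aromatic ring with 2 hetero atoms enters on the same oxygen.

Going by the values given here, no measured pair differs in one place only, so direct evidence for the size of this step is missing. The closest guide is compound 2, which carries the same entering group and gives 1.8. Compound 2 and compound 4 are still different structures, so this guide is imperfect. A downward move beyond the scatter is expected, and the estimated size is a number 0.70 log units lower from compound 3 to compound 4 (beyond the scatter). For compound 4 the estimated value is 1.9, with an expected range from 1.5 to 2.2.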

Compound 4, distribution coefficient: 2
The estimate for compound 4 lay 0.10 log units below the measured number; measured number inside the range.
By their numbers in this assay, from the lowest: compounds 2 and 4 (each within the scatter of the next); then compounds 1 and 3 (each within the scatter of the next).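

At this oxygen on a saturated carbon, the exchange of oxetan-3-yl for the group with one six-membered aromatic ring with 2 hetero atoms now has a direct reading in this assay: a number 0.60 log units lower from compound 3 to compound 4 (beyond the scatter). Going by these compounds alone, this is the first single-place step, and it shows that the change of group at this position moves the number beyond the scatter. The configuration as drawn gives a number 0.20 log units higher from compound 2 to compound 4 (within the scatter), so the two stereocentres at the saturated ring carbons do not separate this pair in this assay, a reading that can be made cleanly for one reason: the fact that compounds 2 and 4 differ only in the configuration as drawn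

The compounds shown leave open how an amine or a carboxylic acid on the same oxygen would read in this assay. They also leave open whether oxetan-3-yl, shown here in one configuration only, would be equally insensitive to the configuration as drawn.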